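Swapping the halogenated ring on compound 2

The source may report more compounds than this note shows. Statements on the series, on what has been measured and on what is new or still open speak of the compounds shown alone.

Two compounds have numbers in a functional assay on HT-29 cells (Homo sapiens) for inhibition, read by MTT assay, with a stated time of 120 h; on this read-out lower numbers stand for stronger inhibition and higher numbers for weaker inhibition. Compound 1, with the structure `CNC(=O)C#Cc1ccc(NC(=O)Nc2ccc(Cl)c(C(F)(F)F)c2)cc1`, gives 14000 nM in this assay. Compound 2, with the structure `CC(NC(=O)c1ccc(-c2ccc(NC(=O)Nc3cc(C(F)(F)F)ccc3Cl)cc2)cc1)c1ccccc1`, gives 6570 nM in this assay. Of these two numbers, compound 2 carries the lower one, and the gap to compound 1 lies beyond the usual scatter of repeated runs. Among the measured compounds shown here, no pair of measured compounds differing in a single place is available, so no measured step can be quoted.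

Compound 3, with the structure `CC(NC(=O)c1ccc(-c2ccc(NC(=O)Nc3ccc(Cl)c(C(F)(F)F)c3)cc2)cc1)c1ccccc1`, has not yet been measured. It differs from compound 2 in one place: 4-chloro-3-(trifluoromethyl)phenyl in place of 2-chloro-5-(trifluoromethyl)phenyl on an amide-type nitrogen. The two compounds contain the same atoms, joined differently.

For the measured compounds named here, since the only measured comparison does not isolate this change, the direction of the step is uncertain. He expects compound 3 to land near compound 2, with the step from compound 2 to compound 3 estimated as a 1.5-fold lower number from compound 2 to compound 3 (0.16 log units; within the scatter), not clearly beyond the scatter. His estimate for compound 3 in this assay is 4500 nM, within a range from 1500 nM to 14000 nM.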

Compound 3, half-maximal inhibitory concentration: 5960 nM
The estimate for compound 3 lay 1.3-fold (0.12 log units) below the measured number, and the stated range covers the measured number.
By their numbers in this assay, from the lowest: compounds 3 and 2 (each within the scatter of the next); then compound 1.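

In this assay, compound 3 carries 4-chloro-3-(trifluoromethyl)phenyl in place of the 2-chloro-5-(trifluoromethyl)phenyl of compound 2 on the amide-type nitrogen, and the exchange gives a 1.1-fold lower number from compound 2 to compound 3 (0.04 log units; within the scatter) on the otherwise shared core. Among the compounds shown here, this is the first measured pair that isolates a single change, and it shows that these two arrangements of the same atoms on this nitrogen cannot be told apart in this read-out, so the choice between them does not separate the two compounds here. No measurement at hand speaks to why the two groups read alike.

The compounds shown leave open whether a phenyl ring carrying an amine or a carboxylic acid in place of the chlorine, or a phenyl ring with neither chlorine nor trifluoromethyl, would stay within the scatter of compound 2 on this nitrogen. They also leave open whether the same exchange would read alike on the core of compound 1, which carries the 4-chloro-3-(trifluoromethyl)phenyl group on a different remainder.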